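This account rests on a few compounds, and the source may have more. Where it says the series, first, only, none or still open, it means among the compounds named here.

In a functional assay on NCI-H460 cells (Homo sapiens) for cytotoxicity, read by MTT assay, with a stated time of 72 h (a lower number here means a stronger inhibitor, a higher number a weaker inhibitor), compound 1 (`O=c1[nH]/c(=C\c2cccc(Oc3ccc(F)cc3)c2)c(=O)[nH]/c1=C\c1ccccc1`) gives 389 nM, and compound 2 (`O=c1[nH]/c(=C\c2ccc(Br)o2)c(=O)[nH]/c1=C\c1cccc(Oc2ccc(F)cc2)c1`) gives 361 nM. Among the compounds with values here, compound 2 therefore stands together with compound 1, the only other compound measured so far. The measured step between them is a 1.1-fold lower number from compound 1 to compound 2 (0.03 log units; within the scatter), and it came with 5-bromofuran-2-yl in place of phenyl on a double-bonded chain carbon bound to an aromatic carbon.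

Compound 3 (`CC(C)(C)S(=O)(=O)OCc1ccc(/C=c2\[nH]c(=O)/c(=C/c3cccc(Oc4ccc(F)cc4)c3)[nH]c2=O)o1`) alters compound 2 in one place: (((tert-butyl)sulfonyl)oxy)methyl in place of bromo on an aromatic carbon. In words, this is (((tert-butyl)sulfonyl)oxy)methyl in place of bromo on an aromatic carbon of a five-membered aromatic ring with 1 oxygen, next to the ring oxygen.

Within the data shown here, no measured compound carries this new group, so the evidence is thin. Among the measured compounds shown here, the one step that touches the same part of the molecule is a 1.1-fold lower number from compound 1 to compound 2 (0.03 log units; within the scatter), and it gives no sign of a large shift. No step beyond the scatter is therefore expected in this assay, and no direction can be favoured. The estimated step is a 1.1-fold higher number from compound 2 to compound 3 (0.04 log units; within the scatter). The expected value for compound 3 is 400 nM, within an estimated range of 130 nM to 1200 nM.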

Compound 3, half-maximal inhibitory concentration: 378 nM
Estimate against measurement, compound 3: 1.1-fold (0.02 log units) above, and the stated range covers the measured number.
By their numbers in this assay, from the lowest: compounds 2, 3 and 1 (each within the scatter of the next).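

In this assay, putting (((tert-butyl)sulfonyl)oxy)methyl in place of bromo, on an aromatic carbon of a five-membered aromatic ring with 1 oxygen, gives a 1.0-fold higher number from compound 2 to compound 3 (0.02 log units; within the scatter). The earlier step compared only 5-bromofuran-2-yl with phenyl, so it said nothing about a large group at this place; here a group of 9 heavy atoms, with 3 hydrogen-bond acceptors, stands where 1 heavy atom stood, and the two numbers remain within the scatter of each other. For this pair of compounds, then, the size of the group at this place does not separate the two numbers in this cell assay, although nothing measured here offers an explanation for that result.

Bromo and (((tert-butyl)sulfonyl)oxy)methyl both have no net charge and no hydrogen-bond donors, so it remains open whether an amine or a carboxylic acid at the same place would keep the number in this range. The pair also leaves open whether a simple hydroxymethyl, which keeps the chain carbon but lacks the sulfonyl part, would read the same.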